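The source may hold more compounds than are shown below. What is called first, only, known or untested is meant among the compounds shown, and "the series" means these compounds.

Measured so far in an ADME assay on microsomes from liver (Mus musculus) for metabolic stability, read by LC-MS, using NADPH, tested at 1 uM; a higher number here means that the compound lasts longer, a lower number that the compound disappears faster
compound 1 `N#Cc1cnc(NC(=O)CCCOc2ccccc2)s1` gives 0.25 h
compound 2 `N#Cc1cnc(NC(=O)CCCOc2cccc(C(F)(F)F)c2)s1` gives 0.517 h

Compound 2 holds the higher of the two numbers. Among the measured compounds shown here, the one measured step is a 2.1-fold higher number from compound 1 to compound 2 (0.32 log units; beyond the scatter) on going to trifluoromethyl in place of hydrogen on an aromatic carbon, a modest move. Compound 3 `N#Cc1cnc(NC(=O)CCCOc2cccc(Cl)c2)s1` carries the change (chloro in place of trifluoromethyl on an aromatic carbon). For the measured compounds named here, no chloro compound has been measured, so that single step is the only guide to size. A small downward move in this assay is expected, no larger than a 2.1-fold higher number from compound 1 to compound 2 (0.32 log units; beyond the scatter) and probably inside the scatter. The estimated step is a 1.3-fold lower number from compound 2 to compound 3 (0.11 log units; within the scatter) in this series. Compound 3 is expected at 0.4 h with an estimated range from 0.22 h to 0.75 h for this half-life.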

Compound 3, half-life: 0.133 h
For compound 3 the middle estimate is 3.0-fold (0.48 log units) above the measured one; the measured number lies below the stated range.
By their numbers in this assay, from the lowest: compounds 3 and 1 (each within the scatter of the next); then compound 2.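

In this assay the exchange of trifluoromethyl for chloro, meta to a large group, is a 3.9-fold lower number from compound 2 to compound 3 (0.59 log units; beyond the scatter) and so is not a neutral swap at this place. Chloro in place of hydrogen is a 1.9-fold lower number from compound 1 to compound 3 (0.27 log units; within the scatter) and cannot be told apart from hydrogen here, which leaves trifluoromethyl as the only one of the three groups that separates from the others, with a 2.1-fold higher number from compound 1 to compound 2 (0.32 log units; beyond the scatter) as its step from hydrogen. Nothing available here bears on the cause of this difference.

Going by these compounds, whether other groups at this place, such as methoxy, fluoro or a dimethylamino group, would follow compound 2 or compound 3 remains open. Also open, on these data alone, is whether trifluoromethyl on another carbon of the ring, or with a shorter chain to the amide, would give a similar half-life.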